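A few compounds are considered here, and "the series" means these few. Any claim that something is new, unique, unknown or untested is made for them only; others in the source may bear on it.

Of the compounds shown here, two of a shared core have been measured in a functional assay on cells (Colon carcinoma cell, Homo sapiens) for cytotoxicity; on this read-out lower numbers stand for an effect already at smaller amounts and higher numbers for an effect only at larger amounts of compound. Compound 1 `COC1=C(OC)[C@@]2(OC)c3c(OC)c(OC)c4c(c3O[C@@]23O[C@@H](c2ccccc2)CC=C3C1=O)[C@@H](OC)C[C@H](c1ccccc1)O4` gives 0.3 ug/mL, and compound 2 `COC1=C(OC)[C@@]2(OC)c3c(O)c(OC)c4c(c3O[C@@]23O[C@@H](c2ccccc2)CC=C3C1=O)[C@@H](OC)C[C@H](c1ccccc1)O4` gives 0.4 ug/mL. Compound 2 thus holds the higher of the two numbers, but the step between them is a 1.3-fold higher number from compound 1 to compound 2 (0.12 log units; within the scatter), so the two values cannot be told apart. That step exchanged a methyl on an oxygen attached to an aromatic ring for a hydrogen, and the read-out did not move beyond its scatter.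

Compound 3 `COC1=C(OC)[C@@]2(OC)c3c(O)c(OC)c4c(c3O[C@@]23O[C@@H](c2ccccc2)CC=C3C1=O)[C@@H](O)C[C@H](c1ccccc1)O4` takes the same kind of change one place further: hydrogen in place of methyl on an oxygen on a saturated carbon. For the measured compounds named here, no measured step touches this particular oxygen, so the only guide is the step from compound 1 to compound 2, where removing a methyl from an oxygen left the number essentially unchanged. On that basis the step of a 1.3-fold higher number from compound 2 to compound 3 (0.10 log units; within the scatter) is expected to be small and within the scatter, with at most a slight drift toward a higher number. Compound 3 is therefore estimated at 0.5 ug/mL in this assay, with a range from 0.2 ug/mL to 1.5 ug/mL.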

Compound 3, half-maximal effective concentration: 0.3 ug/mL
Estimate against measurement, compound 3: 1.7-fold (0.22 log units) above; low and high end bracket the measured number.
By their numbers in this assay, from the lowest: compounds 1, 3 and 2 (each within the scatter of the next).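

In this assay the change from methoxy to hydroxy on the saturated carbon comes out as a 1.3-fold lower number from compound 2 to compound 3 (0.12 log units; within the scatter) and so cannot be told apart from no change at all. Until now, only an oxygen on an aromatic ring had lost its methyl, in a 1.3-fold higher number from compound 1 to compound 2 (0.12 log units; within the scatter), and compound 3 shows that an oxygen of a different kind, on a saturated carbon, can also carry hydrogen instead of methyl with no change beyond the scatter. No measurement other than this one read-out bears on the result, so the compounds offer no explanation for why the number holds.

From the compounds shown here alone, this oxygen has so far carried only a methyl or a hydrogen, so it remains open whether a larger group there, such as a longer alkyl chain or an acetyl group, or an amine in place of the oxygen, would shift the number beyond the scatter. Going by these compounds, it also remains open whether the other methoxy groups on the shared core can be exchanged for hydroxy just as freely.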